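This account rests on a few compounds, and the source may have more. Where it says the series, first, only, none or still open, it means among the compounds named here.

In a functional assay on Jurkat cells (Homo sapiens) for inhibition, read by MTT assay, with a stated time of 72 h (a higher number here means a weaker inhibitor, a lower number a stronger inhibitor), compound 1 (`COc1cccc(/C=C/C(=O)Nc2cc(OC)c(OC)c(OC)c2)c1`) gives 12500 nM, compound 2 (`COc1cc(NC(=O)/C=C/c2cccc(OCc3ccccc3)c2)cc(OC)c1OC`) gives 3500 nM and compound 3 (`C=C(Br)C(=O)Nc1cccc(/C=C/C(=O)Nc2ccccc2)c1`) gives 5000 nM. Compound 3 thus lies within the scatter of compound 2 and has a lower number than compound 1, by a margin beyond the scatter.

Compound 4 (`C=C(Br)C(=O)Nc1cccc(/C=C/C(=O)Nc2ccc(SC(F)(F)F)cc2)c1`) differs from compound 3 in one place: (trifluoromethyl)sulfanyl in place of hydrogen on an aromatic carbon. This is (trifluoromethyl)sulfanyl in place of hydrogen on an aromatic carbon. Within the data shown here, no measured step shows this same change. The closest guide is a 3.6-fold lower number from compound 1 to compound 2 (0.55 log units; beyond the scatter), with phenyl in place of hydrogen on a saturated chain carbon bound to an oxygen on an aromatic ring. That single step adds a different group at a different place, so it bears only loosely on this change. A modest step of similar size towards a lower number in this assay is expected, though a result within the scatter would not be surprising.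

The estimated value for compound 4 is 1600 nM, with an expected range of 400 nM to 5500 nM. This estimate means an expected step of a 3.1-fold lower number from compound 3 to compound 4 (0.49 log units; beyond the scatter).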

Compound 4, half-maximal inhibitory concentration: 30100 nM
Compound 4: middle estimate off by 19-fold (1.27 log units), on the low side; the whole stated range lies below it.
By their numbers in this assay, from the lowest: compounds 2 and 3 (each within the scatter of the next); then compound 1; then compound 4.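

In this assay, (trifluoromethyl)sulfanyl on this aromatic carbon, para to a large group, gives a 6.0-fold higher number from compound 3 to compound 4 (0.78 log units; beyond the scatter), the only step shown that moves towards a higher number. The earlier step, a 3.6-fold lower number from compound 1 to compound 2 (0.55 log units; beyond the scatter), ran the other way with a different group at a different place, so adding heavy atoms does not lower the number in every case shown. Nothing available accounts for the rise at this position.

The compounds shown carry only hydrogen or (trifluoromethyl)sulfanyl on this carbon, so it remains open whether the higher number belongs to this particular group or to substitution here in general. A single fluorine atom, an amine or a carboxylic acid at the same place would help separate these two readings.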